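Chloro step on compound 1: working notes

A few compounds are considered here, and "the series" means these few. Any claim that something is new, unique, unknown or untested is made for them only; others in the source may bear on it.

Among the compounds with values here, compound 1 `C(=C/c1ccccc1)\C(=N\Nc1nncc2ccccc12)c1ccccc1` gives 2.4 nM in a functional assay on COLO 205 cells (Homo sapiens) for antiproliferative activity, read by sulforhodamine B assay, with a stated time of 72 h (on this read-out lower numbers stand for stronger inhibition and higher numbers for weaker inhibition), and holds the lower of the two numbers so far. Within the data shown here, the only other measured compound is compound 2 `S=C(NNc1nncc2ccccc12)Nc1ccccc1` at 77 nM in this assay and its number is higher, with the gap beyond the scatter. Among the measured compounds shown here, no measured pair differs in one place, so the data hold no direct precedent for substitution on this ring.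

Compound 3 `Clc1ccc(C(/C=C/c2ccccc2)=N\Nc2nncc3ccccc23)cc1` has chloro in place of hydrogen on an aromatic carbon and thus turns phenyl to 4-chlorophenyl. No step beyond the scatter is expected in this assay and no direction is favoured, so the expectation rests on compound 1 at 2.4 nM as its anchor. The estimated 1.3-fold higher number from compound 1 to compound 3 (0.10 log units; within the scatter) is expected to stay within the scatter. Compound 3 is estimated at 3 nM with an expected range of 1 nM to 10 nM in this series.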

Compound 3, half-maximal inhibitory concentration: 5.7 nM
For compound 3 the middle estimate is 1.9-fold (0.28 log units) below the measured one, within the range that was stated.
By their numbers in this assay, from the lowest: compound 1; then compound 3; then compound 2.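

In this assay, within the data shown here, chloro in place of hydrogen on an aromatic carbon, para to a large group, gives a 2.4-fold higher number from compound 1 to compound 3 (0.38 log units; beyond the scatter) and so provides the first direct reading for substitution on this ring. The change from phenyl to 4-chlorophenyl is modest but not neutral at this position, and compound 3 at 5.7 nM still shows that this carbon tolerates one added chlorine atom without a large loss on this read-out. Nothing measured here accounts for the step.

From the compounds shown here alone, a single substituent at a single place gives no trend, so it remains open how a fluoro, a methoxy or an amine at this carbon would compare with chloro. Also open, going by these compounds, is whether chloro on the other phenyl of compound 1 would give a step of similar size and direction.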